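Methyl scan on the shared core: the position next to nitrogen

The source may report more compounds than this note shows. Statements on the series, on what has been measured and on what is new or still open speak of the compounds shown alone.

Compound 1 `N/C(=N\NC(=S)N1CCCCCC1)c1ccccn1` is the reference point. Within the data shown here, in a functional assay on MCF7 cells (Homo sapiens) for cytotoxicity, read by MTT assay, with a stated time of 72 h (on this read-out lower numbers stand for stronger inhibition and higher numbers for weaker inhibition), compound 1 gives 2600 nM, the lowest of the two numbers measured so far. Compound 2 `Cc1ccnc(/C(N)=N/NC(=S)N2CCCCCC2)c1` carries a methyl on the aromatic ring and in this assay compound 2 gives 6900 nM; the step of a 2.7-fold higher number from compound 1 to compound 2 (0.42 log units; beyond the scatter) shows a modest loss. Compound 3 `Cc1cccc(/C(N)=N/NC(=S)N2CCCCCC2)n1` is not yet measured. It differs from compound 1 by methyl in place of hydrogen on an aromatic carbon, the methyl sitting next to the ring nitrogen, meta to a large group. Among the measured compounds shown here, the only step that bears on this is the one from compound 1 to compound 2, a methyl at another ring position, which went beyond the scatter toward weaker inhibition. A similar, modest step in the same direction is therefore expected for compound 3 in this assay, namely a 2.1-fold higher number from compound 1 to compound 3 (0.33 log units; beyond the scatter). For compound 3 the estimate in this assay is 5500 nM, with a range from 2000 nM to 15000 nM.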

Compound 3, half-maximal inhibitory concentration: 54700 nM
Estimate against measurement, compound 3: 9.9-fold (1.00 log units) below; measured number outside the range, above it.
By their numbers in this assay, from the lowest: compound 1; then compound 2; then compound 3.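

In this assay, methyl in place of hydrogen on an aromatic carbon next to the ring nitrogen gives a 21-fold higher number from compound 1 to compound 3 (1.32 log units; beyond the scatter) and is a large step, whereas the methyl of compound 2 at its other ring position gave only a 2.7-fold higher number from compound 1 to compound 2 (0.42 log units; beyond the scatter) as a modest one. The same added methyl therefore does not cost the same at every place on this ring, and of the two places seen, the one next to the ring nitrogen is much the less tolerant. No measurement here bears on the reason for this difference.

On these data alone, whether the loss belongs to methyl itself or to any substituent at this position remains open, and a fluorine, a methoxy group or an amine there would help to separate the two. Also open, as far as these compounds go, is how a longer chain such as ethyl would behave at this position.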